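This account rests on a few compounds, and the source may have more. Where it says the series, first, only, none or still open, it means among the compounds named here.

Measured so far in a functional assay on HeLa cells (Homo sapiens) for cytotoxicity, read by MTT assay, with a stated time of 72 h; on this read-out higher numbers stand for weaker inhibition and lower numbers for stronger inhibition:
compound 1 `Cc1cc(S(=O)(=O)/N=C(\N)n2nccc2-c2ccccc2)c(SCc2cccc(Cl)c2)cc1Cl` gives 10000 nM
compound 2 `Cc1cc(S(=O)(=O)/N=C(\N)n2nccc2-c2ccccc2)c(SCc2cccc(C(F)(F)F)c2)cc1Cl` gives 19000 nM

For the measured compounds named here, compound 2 has the higher of the two numbers, and its only neighbour is compound 1; the step between them, a 1.9-fold higher number from compound 1 to compound 2 (0.28 log units; within the scatter), is small enough to count as noise, so on these data the two compounds are indistinguishable. The next compound, compound 3 `Cc1cc(S(=O)(=O)/N=C(\N)n2nccc2-c2ccccc2)c(SCc2ccc(Cl)cc2)cc1Cl`, carries the change (4-chlorophenyl in place of 3-(trifluoromethyl)phenyl on a saturated chain carbon bound to a sulfur). Going by the values given here, only one measured step touches this kind of change: the swap of trifluoromethyl for chloro at the same position, a 1.9-fold higher number from compound 1 to compound 2 (0.28 log units; within the scatter), which stayed within the scatter. Among the compounds with values here, no measured pair shows a chloro moved from one position of the benzyl ring to another, so that part of the change has no precedent here. The expected step in this assay , a 1.6-fold lower number from compound 2 to compound 3 (0.20 log units; within the scatter), is therefore none beyond the scatter, with a slight lean back toward the number of compound 1. Compound 3 is estimated at 12000 nM, with a range from 5000 nM to 30000 nM.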

Compound 3, half-maximal inhibitory concentration: 3000 nM
Compound 3: middle estimate off by 4.0-fold (0.60 log units), on the high side, and the stated range ends above it.
By their numbers in this assay, from the lowest: compound 3; then compounds 1 and 2 (each within the scatter of the next).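

In this assay, the step from 3-chlorophenyl to 4-chlorophenyl on the saturated chain carbon bound to a sulfur is a 3.3-fold lower number from compound 1 to compound 3 (0.52 log units; beyond the scatter) and lies beyond the scatter, whereas exchanging chloro for trifluoromethyl at the same ring place gave a 1.9-fold higher number from compound 1 to compound 2 (0.28 log units; within the scatter) and stayed within it. The change from 3-(trifluoromethyl)phenyl to 4-chlorophenyl, a 6.3-fold lower number from compound 2 to compound 3 (0.80 log units; beyond the scatter) and also beyond the scatter, leaves compound 3 as the most potent of the three, so where the chloro sits on this ring affects the read-out. Nothing measured here accounts for this difference.

From the compounds shown here alone, it remains open whether this lower number is specific to 4-chlorophenyl or would also appear with 4-fluorophenyl or 4-methoxyphenyl at the same place. Also open, going by these compounds, is whether a phenethyl group could take the place of the 4-chlorobenzyl group and keep it.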